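Series notes: side-chain trimming on compound 1

The compounds below may be only part of what the source reports. "The series", "measured", "known", "first", "only" and "open" are said of these compounds alone.

Measured so far:
- compound 1, `Cn1ncc(Cl)c1-c1cc(C(=O)N[C@@H]2CN[C@H](CC(O)CO)C[C@H]2c2ccc(Cl)c(Cl)c2)oc1Cl`, in a functional assay on OVCAR-8 cells (Homo sapiens) for antiproliferative activity; a lower number here means a stronger inhibitor, a higher number a weaker inhibitor: 1610 nM
- compound 2, `O=C(N[C@@H]1CNCC[C@H]1c1ccc(Cl)cc1)c1ccc(-c2ncnc3c2CCC3O)s1`, in this assay: 24100 nM

Going by the values given here, compound 1 holds the lower of the two numbers known in this assay; compound 2 sits beyond the scatter above it. Compound 3, `CCC[C@@H]1C[C@@H](c2ccc(Cl)c(Cl)c2)[C@H](NC(=O)c2cc(-c3c(Cl)cnn3C)c(Cl)o2)CN1`, is yet to be measured in this assay. It differs from compound 1 by ethyl in place of 1,2-dihydroxyethyl on a saturated chain carbon bound to a saturated ring carbon. Among the compounds with values here, no step between measured compounds bears on this change, so nothing beyond the scatter is expected in either direction. The expected step is a 1.1-fold lower number from compound 1 to compound 3 (0.03 log units; within the scatter). Compound 3 is estimated at 1500 nM, within 500 nM to 5000 nM.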

Compound 3, half-maximal inhibitory concentration: 1620 nM
The estimate for compound 3 lay 1.1-fold (0.03 log units) below the measured number; low and high end bracket the measured number.
By their numbers in this assay, from the lowest: compounds 1 and 3 (each within the scatter of the next); then compound 2.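

In this assay, going by these compounds alone, the exchange of 1,2-dihydroxyethyl for ethyl on a saturated chain carbon bound to a saturated ring carbon reads a 1.0-fold higher number from compound 1 to compound 3 (0.00 log units; within the scatter) and so gives the first direct comparison at this position. On the core of compound 1, the two groups cannot be told apart in this read-out. No available measurement accounts for this result.

Open, on these data alone, is whether an amine or a carboxylic acid on this chain would also stay within the scatter of compound 1. As far as these compounds go, a longer chain, such as hexyl, remains equally open.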